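Swapping the acidic side chain on a quinoline ether core

The source may hold more compounds than are shown below. What is called first, only, known or untested is meant among the compounds shown, and "the series" means these compounds.

Measured compounds:
- compound 1 `CC(CCc1nnn[nH]1)Cc1ccc(OCc2ccc3ccccc3n2)cc1`: 12 nM
- compound 2 `c1ccc(C(CCc2nnn[nH]2)Cc2ccc(OCc3ccc4ccccc4n3)cc2)cc1`: 8 nM
- compound 3 `O=C(O)C1CCC(c2ccc(OCc3ccc4ccccc4n3)cc2)C1`: 43 nM

All three share a core in which a quinoline is linked through an oxygen to a benzene ring; they differ in the side chain on that benzene ring. In an assay on membranes from lung (Cavia porcellus) for binding affinity to cysteinyl leukotriene receptor (Homo sapiens) (on this read-out higher numbers stand for weaker inhibition and lower numbers for stronger inhibition), compound 1 gives 12 nM, the second highest of the three numbers. Compound 2, its nearest neighbour, shows a 1.5-fold lower number from compound 1 to compound 2 (0.18 log units; within the scatter). Within the data shown here, compound 3, the furthest, gives 43 nM and carries a carboxylic acid rather than a tetrazole, though no single-point step links it to compound 1.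

Compound 4 `CCCC(CCC(=O)O)Cc1ccc(OCc2ccc3ccccc3n2)cc1` has not yet been measured. Compared with compound 1 it carries 1-(2-carboxyethyl)butyl in place of 3-(1H-tetrazol-5-yl)-1-methylpropyl on a saturated chain carbon bound to an aromatic carbon. Among the measured compounds shown here, the one measured step, from compound 1 to compound 2, changes a different part of this same side chain and stays within the scatter, so it says little about replacing the tetrazole. The only other hint is that compound 3, the acid-bearing compound, gives the highest of the three numbers.

Compound 4 is therefore expected to sit somewhat higher than compound 1, with a 2.5-fold higher number from compound 1 to compound 4 (0.40 log units; beyond the scatter) as the estimated step. The estimate for compound 4 in this assay is 30 nM, with a range from 10 nM to 90 nM.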

Compound 4, inhibition constant: 21 nM
Estimate against measurement, compound 4: 1.4-fold (0.15 log units) above; the measured number falls inside the stated range.
By their numbers in this assay, from the lowest: compounds 2, 1 and 4 (each within the scatter of the next, the first and the last beyond it); then compound 3.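

Among these compounds, this is the first direct one-place comparison of a tetrazole-bearing chain with a carboxylic acid-bearing chain on this core: in this assay, the swap gives a 1.8-fold higher number from compound 1 to compound 4 (0.24 log units; within the scatter). On a saturated chain carbon bound to an aromatic carbon, then, 3-(1H-tetrazol-5-yl)-1-methylpropyl can give way to 1-(2-carboxyethyl)butyl, which has no ring, with no change that this assay can resolve, so in this pair the five-membered aromatic ring is not needed for a number in this range. Nothing available explains why the two groups read alike.

The swap replaces the tetrazole and reshapes the rest of the chain in one step, so the compounds shown cannot say what each of these two changes contributes alone. From the compounds shown here alone, it also remains open whether a methyl ester or a primary amide in place of the carboxylic acid of compound 4, or a longer chain carrying that acid, would stay in the same range.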